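Chloro to propyl on the core of compound 1

The source may report more compounds than this note shows. Statements on the series, on what has been measured and on what is new or still open speak of the compounds shown alone.

Measured so far in an assay on isolated protein for inhibition of tyrosine-protein kinase receptor UFO (Homo sapiens), read by FRET and Z'-LYTE, with a stated time of 1.5 h; on this read-out lower numbers stand for stronger inhibition and higher numbers for weaker inhibition:
compound 1, `Cc1c(C(=O)Nc2ccc(Oc3ncnc4[nH]cc(-c5ccccc5)c34)c(F)c2)c(=O)c2cc(Cl)ccc2n1C`: 1890 nM
compound 2, `CCc1ccc2c(c1)c(=O)c(C(=O)Nc1ccc(Oc3ncnc4[nH]ccc34)c(F)c1)c(C)n2C`: 157 nM
compound 3, `CCc1ccc2c(c1)c(=O)c(C(=O)Nc1ccc(Oc3ccnc4[nH]cc(-c5ccccc5)c34)c(F)c1)c(C)n2C`: 30 nM

Compound 1 stands at the highest number of the three, with compound 2 nearest and compound 3 furthest, both steps beyond the scatter. Among the measured compounds shown here, compound 1 differs from compound 2 and from compound 3 in more than one place, so none of these pairs isolates a single change and no computed step between measured compounds is available.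

Compound 4, `CCCc1ccc2c(c1)c(=O)c(C(=O)Nc1ccc(Oc3ncnc4[nH]cc(-c5ccccc5)c34)c(F)c1)c(C)n2C`, is not yet measured. It is compound 1 with one change: propyl in place of chloro on an aromatic carbon. The remaining structure of compound 1 is kept. Compound 2 and compound 3 both carry an ethyl group at this place on the core and give lower numbers than compound 1, but their other differences leave open how much of that comes from the group at this place.

In this assay the step from compound 1 to compound 4 is expected to be a decrease beyond the scatter, of moderate size, a 4.2-fold lower number from compound 1 to compound 4 (0.62 log units; beyond the scatter). The estimate for compound 4 is 450 nM, with a range from 120 nM to 1500 nM.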

Compound 4, half-maximal inhibitory concentration: 61 nM
For compound 4 the middle estimate is 7.4-fold (0.87 log units) above the measured one, outside the stated range (below it).
By their numbers in this assay, from the lowest: compound 3; then compound 4; then compound 2; then compound 1.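

Working notes on the position: in this assay, a 31-fold lower number from compound 1 to compound 4 (1.49 log units; beyond the scatter) when propyl replaces chloro on an aromatic carbon and the rest of compound 1 is kept. Among the compounds shown here, this is the first step that isolates a single change, so the group at this place on the shared core can by itself move the number by a large amount, which compounds 2 and 3 could not show with their other differences. Nothing available bears on why this swap has so large an effect.

With only chloro and propyl compared on an otherwise unchanged structure, the result does not separate the loss of chloro from the gain of propyl, and it does not show how the number would respond here to a butyl chain, a methoxy group or an amine. From the compounds shown here alone, whether a step of this size would carry over to the other variations also remains open, as compound 2 and compound 3 each differ from compound 4 in more than one place.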